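Anilino substitution in a thiazolyl acetamide series

This account rests on a few compounds, and the source may have more. Where it says the series, first, only, none or still open, it means among the compounds named here.

Measured compounds
compound 1: `Cc1nc(SCC(=O)Nc2nc(-c3ccc(Cl)cc3)cs2)n(Nc2ccccc2)c1C`, 3600 nM
compound 2: `Cc1ccc(Nn2c(SCC(=O)Nc3nc(-c4ccccc4)cs3)nc(C)c2C)cc1`, 4410 nM

In a functional assay on 786-0 cells (Homo sapiens) for antiproliferative activity, read by sulforhodamine B assay, with a stated time of 48 h (a higher number here means a weaker inhibitor of growth, a lower number a stronger inhibitor of growth), compound 1 gives 3600 nM, the lowest of the two numbers recorded. Among the measured compounds shown here, compound 2 gives 4410 nM in this assay, a gap from compound 1 that lies within the scatter, so the two are read as equivalent; the pair also differs in two places and no single step is defined between them.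

Compound 3, `COc1ccc(Nn2c(SCC(=O)Nc3nc(-c4ccc(Cl)cc4)cs3)nc(C)c2C)cc1`, has not been measured. Relative to compound 1 the change is methoxy in place of hydrogen on an aromatic carbon. With no measured step of this kind in the series, the expectation is for a step from compound 1 that stays within the scatter, in either direction, as expected by a 1.0-fold lower number from compound 1 to compound 3 (0.01 log units; within the scatter). Compound 3 is therefore estimated at 3500 nM in this assay, with a range from 1500 nM to 8000 nM.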

Compound 3, concentration for 50% growth inhibition: 3460 nM
The estimate for compound 3 lay 1.0-fold (0.00 log units) above the measured number; measured number inside the range.
By their numbers in this assay, from the lowest: compounds 3, 1 and 2 (each within the scatter of the next).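

In this assay the change from anilino to (4-methoxyphenyl)amino reads as a 1.0-fold lower number from compound 1 to compound 3 (0.02 log units; within the scatter) and gives the series its first step in a single place. This position, on the six-membered aromatic ring and para to a large group, therefore accepts methoxy in place of hydrogen with no reading beyond the scatter, so compound 1 and compound 3 count as equivalent. Nothing at hand accounts for this equivalence.

As far as these compounds go, one group at one place cannot define the tolerance of this position, so it remains open whether a carboxylic acid, an amine or a longer chain such as butoxy would also read alike. From the compounds shown here alone, it is equally open whether methoxy would behave the same way on the core of compound 2.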